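The compounds below may be only part of what the source reports. "The series", "measured", "known", "first", "only" and "open" are said of these compounds alone.

Of the compounds shown here, three have been measured so far in a functional assay on L1210 cells (Mus musculus) for antiproliferative activity; on this read-out lower numbers stand for lower potency and higher numbers for higher potency (the scale is a negative logarithm). Compound 1 `CN(C)/N=N/c1ccc(CCCC(=O)NN)cc1` gives 3.6 in this assay. Compound 2 `CN(/N=N/c1nc[nH]c1C(N)=O)c1cccs1` gives 3.87, and compound 3 `C#CCN(C)/N=N/c1nc[nH]c1C(N)=O` gives 3.61. Compound 3 thus stands second among the three numbers, but both neighbours lie within the scatter of it, so the three cannot be told apart on these numbers. Within the data shown here, the one measured step on the shared core of compound 2 and compound 3 is a number 0.26 log units lower from compound 2 to compound 3 (within the scatter), an exchange on the amine nitrogen that left the number essentially unchanged.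

Compound 4 `CC(C)CN(C)/N=N/c1nc[nH]c1C(N)=O` is not yet measured. It differs from compound 3 in one place: isopropyl in place of ethynyl on a saturated chain carbon bound to an amine nitrogen. Among the measured compounds shown here, no measured pair shows what isobutyl in place of propargyl does; the only comparable step is the one just described, and it stayed within the scatter. With nothing pointing in either direction, no shift beyond the scatter is expected in this assay. Compound 4 is therefore estimated at 3.6, with a range from 3.2 to 4. This expectation implies a step of a number 0.01 log units lower from compound 3 to compound 4 (within the scatter), within the usual scatter.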

Compound 4, logarithm of the reciprocal of the active concentration, log(1/C): 3.51
Estimate against measurement, compound 4: 0.09 log units above; low and high end bracket the measured number.
By their numbers in this assay, from the lowest: compounds 4, 1, 3 and 2 (each within the scatter of the next, the first and the last beyond it).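

In this assay, going from propargyl to isobutyl gives a number 0.10 log units lower from compound 3 to compound 4 (within the scatter), so on these numbers the ethynyl end of the chain can be exchanged for isopropyl with no change that can be told apart from scatter. Thiophen-2-yl to isobutyl on the same amine nitrogen gives a number 0.36 log units lower from compound 2 to compound 4 (beyond the scatter), a modest step and the only one at this nitrogen among the compounds shown that passes the scatter. Nothing measured here offers an explanation for either step.

The compounds shown leave open whether a longer chain, a chain ending in an amine or a carboxylic acid on this amine nitrogen would move the number beyond the scatter from that of compound 3. They also leave open whether a phenyl ring in place of thiophen-2-yl would give a number like that of compound 2.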